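Changing the ring configuration of compound 2

A few compounds are considered here, and "the series" means these few. Any claim that something is new, unique, unknown or untested is made for them only; others in the source may bear on it.

Compound 2 `O=C(O)CC/C=C\C[C@@H]1CN(S(=O)(=O)c2cccc3cnccc23)C[C@H]1c1ccccc1O` gives the lowest number of the three measured in a functional assay on the whole organism (trachea) for inhibition, with Cavia porcellus as the target (a higher number here means that more compound is needed for the effect, a lower number that less compound is needed), at 0.056 mg/kg. Compound 1 `O=C(O)CCC/C=C\C[C@@H]1CN(S(=O)(=O)c2cccc3ccccc23)C[C@@H]1c1ccccc1O` gives 0.08 mg/kg in this assay, and compound 3 `O=C(O)CC/C=C\C[C@@H]1CN(S(=O)(=O)c2ccc(Cl)cc2)C[C@H]1c1ccccc1O` gives 0.12 mg/kg. Within the data shown here, the one single-point step measured, a 2.1-fold higher number from compound 2 to compound 3 (0.33 log units; beyond the scatter), concerns the sulfonyl group and says nothing about configuration. Compound 4 `O=C(O)CC/C=C\C[C@@H]1CN(S(=O)(=O)c2cccc3cnccc23)C[C@@H]1c1ccccc1O` differs from compound 2 in that (the two compounds have the same atoms and bonds and differ only in configuration as drawn: 1 of 3 stereo elements differ; a stereocentre at a saturated ring carbon is drawn R in compound 2 and S in compound 4). Compound 1 shares the drawn ring configuration of compound 4 but differs from it in two further places, so its value only shows that such a configuration can sit near compound 2. Compound 4 is therefore expected to give 0.1 mg/kg, within 0.03 mg/kg to 0.4 mg/kg, a step of a 1.8-fold higher number from compound 2 to compound 4 (0.25 log units; within the scatter).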

Compound 4, dose for 50% inhibition: 0.011 mg/kg
Beside the measured number, compound 4's estimate is 9.1-fold (0.96 log units) above it, outside the stated range (below it).
By their numbers in this assay, from the lowest: compound 4; then compounds 2, 1 and 3 (each within the scatter of the next, the first and the last beyond it).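

In this assay, among these compounds, the configuration at this saturated ring carbon counts on its own, with a 5.1-fold lower number from compound 2 to compound 4 (0.71 log units; beyond the scatter), a step that none of the earlier comparisons could isolate. The step can be set on this one stereocentre alone, as nothing enters or leaves: the fact that compounds 2 and 4 differ only in the configuration as drawn. With isoquinolin-5-yl on the sulfonyl sulfur, the centre drawn S gives the lower number.

The compounds shown leave open whether this configuration gives a similar step with 4-chlorophenyl on the sulfonyl sulfur. They also leave open how a methyl ester in place of the carboxylic acid would behave with it.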